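Acid dissociation notes on the chain-amine series, compound 4 pending

The compounds below may be only part of what the source reports. "The series", "measured", "known", "first", "only" and "open" are said of these compounds alone.

Three compounds have so far been measured in a physicochemical assay for acid dissociation:

compound 1 `COc1ccc(Oc2ccc3c(NCCCNCc4cc(F)ccc4OC)ccnc3c2)cc1` gives 9.28
compound 2 `COc1ccc(Oc2ccc3c(NCCCNCc4cccc(OC)c4O)ccnc3c2)cc1` gives 9.28
compound 3 `COc1ccc(Oc2ccc3c(NCCCNCc4ccco4)ccnc3c2)cc1` gives 9.28

Compound 2 stands level with compound 1 and compound 3 at the digits printed. The step from compound 1 to compound 2 is no change at the digits printed from compound 1 to compound 2 (within the scatter), that from compound 1 to compound 3 is no change at the digits printed from compound 1 to compound 3 (within the scatter), and that from compound 2 to compound 3 is no change at the digits printed from compound 2 to compound 3 (within the scatter). All three of these steps exchange the group on the saturated chain carbon bound to an amine nitrogen, and none of them moves the read-out beyond the scatter.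

Compound 4 `COc1cccc(CNCCCNc2ccnc3cc(CCc4ccccc4)ccc23)c1O` is not yet measured. Against compound 2 the change is phenethyl in place of 4-methoxyphenoxy on an aromatic carbon. Among the measured compounds shown here, no measured step touches this aromatic carbon of the fused two-ring system, so the only guide is that every exchange tried so far left the read-out unchanged. On that basis the expected step from compound 2 to compound 4 is no change at the digits printed from compound 2 to compound 4 (within the scatter), that is, no change beyond the scatter. Compound 4 is therefore estimated at 9.28, with a range of 8.85 to 9.7, the range widened somewhat because the change sits at a site the measured steps did not probe.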

Compound 4, acid dissociation constant: 9.47
Beside the measured number, compound 4's estimate is 0.19 log units below it; measured number inside the range.
By their numbers in this assay, from the lowest: compounds 1, 2, 3 and 4 (each within the scatter of the next).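

In this assay, the only exchange shown at this aromatic carbon of the shared core, phenethyl in place of 4-methoxyphenoxy, gives a number 0.19 log units higher from compound 2 to compound 4 (within the scatter), so the read-out stays within the scatter at a second site, beyond the group on the saturated chain carbon bound to an amine nitrogen. The exchange is not a small one on paper: the leaving group has 2 hydrogen-bond acceptors and the entering group 0, its 2 oxygens give way to carbon only, and one six-membered aromatic ring of carbon only stands in both groups.

Going by these compounds, both groups at this aromatic carbon carry that ring, so it remains open whether a group without it, such as an amine or a carboxylic acid, would also stay within the scatter in this assay. Phenethyl is also shown only with the 2-hydroxy-3-methoxyphenyl group on the chain, which leaves open its pairing with furan-2-yl or 5-fluoro-2-methoxyphenyl, and the effect of a longer chain between the core and the amine nitrogen is equally open. Nothing available bears on what lies behind this result.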